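This account rests on a few compounds, and the source may have more. Where it says the series, first, only, none or still open, it means among the compounds named here.

Compound 3 `O=C1COc2ccc(-c3cnc(Cl)c(NS(=O)(=O)c4ccc(F)cc4)c3)cc2N1c1ccc(Cl)cc1` gives in a functional assay on A549 cells (Homo sapiens) for antiproliferative activity, read by MTT assay, with a stated time of 72 h (a higher number here means a weaker inhibitor, a lower number a stronger inhibitor), a value of 21600 nM, the highest of the three numbers measured. Compound 2 `COc1ncc(-c2ccc3c(c2)N(c2ccc(F)cc2)C(=O)CO3)cc1NS(=O)(=O)c1ccc(F)cc1` stands nearest to it with 6500 nM, and compound 1 `COc1ccc(N2C(=O)COc3ccc(-c4cnc(OC)c(NS(=O)(=O)c5ccc(F)cc5)c4)cc32)cc1` stands furthest with 1350 nM. Compound 4 `COc1ncc(-c2ccc3c(c2)N(c2ccc(Cl)cc2)C(=O)CO3)cc1NS(=O)(=O)c1ccc(F)cc1` has not been measured; the change from compound 3 is methoxy in place of chloro on an aromatic carbon. Going by the values given here, no measured step exchanges these two groups at this place. Among the compounds with values here, the single measured step, a 4.8-fold higher number from compound 1 to compound 2 (0.68 log units; beyond the scatter), concerns a different aromatic carbon and does not bear directly on the change to compound 4. Compound 2 and compound 4 share the methoxy on the six-membered aromatic ring with one nitrogen and differ elsewhere only by a fluoro against a chloro, so the value of compound 2, 6500 nM, is the closest guide available. Compound 4 is therefore expected to give a lower number than compound 3, with an estimated step of a 3.1-fold lower number from compound 3 to compound 4 (0.49 log units; beyond the scatter). The estimate for compound 4 is 7000 nM, within a range from 2500 nM to 20000 nM.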

Compound 4, half-maximal inhibitory concentration: 8350 nM
Estimate against measurement, compound 4: 1.2-fold (0.08 log units) below, within the range that was stated.
By their numbers in this assay, from the lowest: compound 1; then compounds 2 and 4 (each within the scatter of the next); then compound 3.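

Going by these compounds alone, at the carbon next to the ring nitrogen, methoxy in place of chloro gives in this assay a 2.6-fold lower number from compound 3 to compound 4 (0.41 log units; beyond the scatter), the first measured exchange at this place. At the other changed aromatic carbon, with methoxy held at the first place, chloro in place of fluoro gives a 1.3-fold higher number from compound 2 to compound 4 (0.11 log units; within the scatter), so these two groups are not told apart there, whereas chloro in place of methoxy gives a 6.2-fold higher number from compound 1 to compound 4 (0.79 log units; beyond the scatter). No measurement shown accounts for any of these steps.

Going by these compounds, it remains open whether an amine or an ethoxy group at the carbon next to the ring nitrogen would give a number different from that of methoxy. On these data alone, it also remains open whether the exchange of chloro for methoxy there gives a step of the same size with fluoro or methoxy at the other carbon.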